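The source may report more compounds than this note shows. Statements on the series, on what has been measured and on what is new or still open speak of the compounds shown alone.

Measured compounds in an ADME assay on WI-38 cells (Homo sapiens) for cytotoxicity, read by MTT assay, with a stated time of 3 days; on this read-out higher numbers stand for weaker inhibition and lower numbers for stronger inhibition:
Compound 1 `Cc1ccc(C#Cc2cn(C/C=C\CN3C(=O)c4ccccc4C3=O)c(=O)[nH]c2=O)cc1` gives > 100000 nM, a limit of the assay.
Compound 2 `O=C1c2ccccc2C(=O)N1C/C=C\Cn1cc(C#Cc2ccc(Br)cc2)c(=O)[nH]c1=O` gives 47000 nM.
Compound 3 `CCCCCCC#Cc1cn(C/C=C/CN2C(=O)c3ccccc3C2=O)c(=O)[nH]c1=O` gives 40000 nM.

Compound 3 stands at the lowest of the two numbers in this assay. Its nearest neighbour is compound 2, whose number differs from it only within the usual scatter. The remaining entry, for compound 1, is a limit (the limit of > 100000 nM in this assay, at which 1 of the 3 values shown sits). Compound 4 `CCCCCc1ccc(C#Cc2cn(C/C=C/CN3C(=O)c4ccccc4C3=O)c(=O)[nH]c2=O)cc1` differs from compound 3 in one place: 4-pentylphenyl in place of hexyl on a triple-bonded carbon. Going by the values given here, no measured step covers this exchange. Among the compounds with values here, the only measured step, an at least 2.1-fold lower number from compound 1 to compound 2 (0.32 log units; beyond the scatter), concerns a change on the aromatic carbon of an aryl-alkyne and so bears on it only loosely; it shows that a change at the end of the alkyne can move the number beyond the scatter, while compound 2, itself an aryl-alkyne, sits within the scatter of compound 3. Compound 4, an aryl-alkyne carrying a pentyl chain, is therefore expected to sit near compound 3 or somewhat higher, an expected step of a 1.4-fold higher number from compound 3 to compound 4 (0.14 log units; within the scatter) that need not exceed the scatter. Compound 4 is estimated at 55000 nM, with a range from 20000 nM to 150000 nM.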

Compound 4, half-maximal inhibitory concentration: 25000 nM
For compound 4 the middle estimate is 2.2-fold (0.34 log units) above the measured one; the range from low to high includes it.
By their numbers in this assay, from the lowest: compounds 4, 3 and 2 (each within the scatter of the next). At a limit, above all of these: compound 1.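

Putting 4-pentylphenyl in place of hexyl on a triple-bonded carbon gives a 1.6-fold lower number from compound 3 to compound 4 (0.20 log units; within the scatter). This is the first step shown at this position, and it shows that this assay tolerates the exchange of an open chain for a six-membered aromatic ring of carbon only carrying a pentyl chain, with no shift beyond the scatter, whereas an at least 2.1-fold lower number from compound 1 to compound 2 (0.32 log units; beyond the scatter), a change on the aromatic carbon, does lie beyond it. Nothing available here accounts for this outcome. On these data alone, it remains open whether an amine or a carboxylic acid at the end of the pentyl chain would leave the number in this range. As far as these compounds go, how a plain phenyl group on the same triple-bonded carbon would compare with compound 3 and compound 4 also remains open.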